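The source may report more compounds than this note shows. Statements on the series, on what has been measured and on what is new or still open speak of the compounds shown alone.

Working notes on the ester series, all read in a functional assay on NCI-H460 cells (Homo sapiens) for cytotoxicity, read by MTT assay, with a stated time of 48 h; a higher number here means a weaker inhibitor, a lower number a stronger inhibitor. Compound 1 `C=C1C(=O)O[C@H]2CC3=C[C@H](C/C(C)=C/[C@@H](OC(=O)c4ccc(C(C)=O)cc4)[C@H]12)OC3=O`, with 4-acetylphenyl on the ester carbonyl, gives 2200 nM. Compound 3 `C=C1C(=O)O[C@H]2CC3=C[C@H](C/C(C)=C/[C@@H](OC(=O)C45CCC(C)(C(=O)O4)C5(C)C)[C@H]12)OC3=O` gives 2000 nM, and the comparison is a 1.1-fold lower number from compound 1 to compound 3 (0.04 log units; within the scatter). Compound 2 `C=C1C(=O)O[C@H]2CC3=C[C@H](C/C(C)=C/[C@@H](OC(=O)CCCCBr)[C@H]12)OC3=O`, with 4-bromobutyl at that place, reads > 10000 nM, which is a limit of the assay. Compound 3 therefore stands level with compound 1 and clearly apart from compound 2.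

Compound 4 `C=C1C(=O)O[C@H]2CC3=C[C@H](C/C(C)=C/[C@@H](OC(=O)/C=C/c4cccs4)[C@H]12)OC3=O` is next, and its change from compound 3 is a group of 7 heavy atoms (6 carbon, 1 sulfur; one five-membered aromatic ring with 1 hetero atom) in place of a group of 11 heavy atoms (9 carbon, 2 oxygen; one five-membered non-aromatic ring of carbon only, one five-membered non-aromatic ring with 1 hetero atom), on a carbonyl carbon. The entering 2-(thiophen-2-yl)ethenyl group, placed on a carbonyl carbon, carries one five-membered aromatic ring with 1 hetero atom. Like compound 1 and compound 3, compound 4 thus keeps a ring in this group, unlike the open chain of compound 2.

The closest precedent is the exchange between two different ring-bearing groups, already given above, which stayed within the scatter. The two steps involving the open chain are larger: an at least 4.5-fold higher number from compound 1 to compound 2 (0.65 log units; beyond the scatter) and an at least 5.0-fold lower number from compound 2 to compound 3 (0.69 log units; beyond the scatter). They bear less directly, since compound 4 keeps a ring. No step beyond the scatter is therefore expected in this assay, though a small move toward a higher number is possible. The expected step is a 1.3-fold higher number from compound 3 to compound 4 (0.10 log units; within the scatter). For compound 4 the estimated value is 2500 nM, with an expected range of 900 nM to 7000 nM.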

Compound 4, half-maximal inhibitory concentration: 2900 nM
Compound 4: the middle estimate sits 1.2-fold (0.06 log units) below what was measured, and the stated range covers the measured number.
By their numbers in this assay, from the lowest: compounds 3, 1 and 4 (each within the scatter of the next). At a limit, above all of these: compound 2.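

In this assay, 2-(thiophen-2-yl)ethenyl on the carbonyl carbon does not separate from either of the other ring-bearing groups (a 1.5-fold higher number from compound 3 to compound 4 (0.16 log units; within the scatter); a 1.3-fold higher number from compound 1 to compound 4 (0.12 log units; within the scatter)). This place in the ester therefore tolerates a third kind of ring without a change beyond the scatter: a five-membered aromatic ring with a sulfur atom reads with the acetylphenyl group of compound 1 and the fused non-aromatic group of compound 3, although the entering group is the smallest of the three. Compound 4 also stands clearly apart from the open chain (an at least 3.4-fold lower number from compound 2 to compound 4 (0.53 log units; beyond the scatter)), so compounds 1, 3 and 4 form one group with compound 2 the only one against it, and that last step is a bound and not a size because compound 2 reads at a limit: the limit of > 10000 nM in this assay, at which 1 of the 4 values shown sits.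

On these data alone, whether compound 2 stands apart through its open chain or through its bromine stays open, and a plain pentyl chain or a chain ending in an amine or a carboxylic acid on the same carbonyl carbon would bear on that. As far as these compounds go, how far the tolerance for rings extends is also open, for instance to a pyridine ring or a simple phenyl group.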